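The source may hold more compounds than are shown below. What is called first, only, known or untested is meant among the compounds shown, and "the series" means these compounds.

Measured so far:
compound 1 `COc1ccc(OC)c(Sc2ccc3nnc(-c4ccccc4)n3n2)c1`: 1380 nM
compound 2 `COc1ccc(OC)c(Sc2ccc3nnc(-c4ccn(C)n4)n3n2)c1`: 2760 nM

Among the measured compounds shown here, in an assay on HEK293 cells for inhibition of Leucine-rich repeat serine/threonine-protein kinase 2 (Homo sapiens), read by ELISA, with a stated time of 90 min (a lower number here means a stronger inhibitor, a higher number a weaker inhibitor), compound 2 holds the highest of the two numbers; its nearest neighbour is compound 1, and the only measured step is a 2.0-fold higher number from compound 1 to compound 2 (0.30 log units; within the scatter). Compound 3 `COc1ccc(OC)c(Sc2ccc3nnc(-c4cn(C)nc4C)n3n2)c1` differs from compound 2 by 1,3-dimethyl-1H-pyrazol-4-yl in place of 1-methyl-1H-pyrazol-3-yl on an aromatic carbon. For the measured compounds named here, that single step, a swap of one ring group at the same place, is the only guide, and it stayed within the scatter, so no step beyond the scatter is expected in this assay. The expected step is a 1.1-fold higher number from compound 2 to compound 3 (0.04 log units; within the scatter). Compound 3 is therefore estimated at 3000 nM, within 1000 nM to 9000 nM.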

Compound 3, half-maximal inhibitory concentration: 1260 nM
Estimate against measurement, compound 3: 2.4-fold (0.38 log units) above; measured number inside the range.
By their numbers in this assay, from the lowest: compounds 3, 1 and 2 (each within the scatter of the next, the first and the last beyond it).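

In this assay, among the compounds shown here, the ring group at this place can move the number a little: 1,3-dimethyl-1H-pyrazol-4-yl in place of 1-methyl-1H-pyrazol-3-yl gives a 2.2-fold lower number from compound 2 to compound 3 (0.34 log units; beyond the scatter) and is the first step here beyond the scatter. The same group in place of phenyl gives a 1.1-fold lower number from compound 1 to compound 3 (0.04 log units; within the scatter) and leaves those two compounds indistinguishable. Nothing available explains either step.

The swap from compound 2 to compound 3 both adds a methyl and moves the ring's point of attachment, and these two changes cannot be separated here. Going by these compounds, whether an amine, a carboxylic acid or a longer chain at this place would shift the number further remains open.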